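This account rests on a few compounds, and the source may have more. Where it says the series, first, only, none or still open, it means among the compounds named here.

Measured compounds in a functional assay on T47D cells (Homo sapiens) for inhibition; on this read-out higher numbers stand for weaker inhibition and lower numbers for stronger inhibition:
compound 1 `Oc1cccc(-c2cc(-c3ccc(F)cc3)cc(-c3ccccc3O)n2)c1`, a limit of the assay, > 50000 nM;
compound 2 `Oc1ccc(-c2cc(-c3ccc(F)cc3)cc(-c3ccccc3O)n2)cc1`, likewise a limit of the assay, > 50000 nM;
compound 3 `Oc1ccc(-c2cc(-c3ccc(F)cc3)cc(-c3cccc(O)c3)n2)cc1`, 5000 nM.

Within the data shown here, compound 3 is therefore the only compound of the three with an actual number in this assay; the other two sit at the limit of > 50000 nM in this assay, at which 2 of the 3 values shown sit. The two readable steps both lead to compound 3: an at least 10-fold lower number from compound 1 to compound 3 (1.00 log units; beyond the scatter) and an at least 10-fold lower number from compound 2 to compound 3 (1.00 log units; beyond the scatter), each a change of where the hydroxyl sits on one of the phenyl rings.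

Compound 4 `Oc1ccc(-c2cc(-c3ccccc3C(F)(F)F)cc(-c3cccc(O)c3)n2)cc1` is not yet measured. It differs from compound 3 in a different place: 2-(trifluoromethyl)phenyl in place of 4-fluorophenyl on an aromatic carbon. Among the measured compounds shown here, none of the measured steps touches this ring; all of them move a hydroxyl on one of the other two rings, so no measured step bears on the change from compound 3 to compound 4, and its size is unknown from the data. For the measured compounds named here, with no precedent, the expected outcome in this assay is a step of no clear size or direction, most likely within the scatter, with wide uncertainty: no change at the digits printed from compound 3 to compound 4 (within the scatter). Compound 4 is thus estimated at 5000 nM, with a range from 1500 nM to 20000 nM.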

Compound 4, half-maximal inhibitory concentration: 3210 nM
Compound 4: the middle estimate sits 1.6-fold (0.19 log units) above what was measured; low and high end bracket the measured number.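

With this assay as the read-out, the swap of 4-fluorophenyl for 2-(trifluoromethyl)phenyl gives a 1.6-fold lower number from compound 3 to compound 4 (0.19 log units; within the scatter). Among these compounds, this is the first information on the ring opposite the ring nitrogen, as every earlier step moved a hydroxyl on one of the other two rings. Here a group of 10 heavy atoms replaces one of 7, and the group's fluorine count and substitution place both change, yet the step stays within the scatter, unlike the two steps that lead to compound 3 from the compounds with a 2-hydroxyphenyl group.

Only these two fluorinated phenyl groups have been shown at this position, so the data cannot separate the effect of the trifluoromethyl group from that of its place on the ring, and they leave open how an amine, a carboxylic acid or a longer alkyl chain would read there. The step between compound 1 and compound 2 also cannot be read, as both compounds stand at a limit and not at a number: the limit of > 50000 nM in this assay, at which 2 of the 4 values shown sit.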